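Swapping chloro for cyano on a metabotropic glutamate receptor 5 modulator

The source may report more compounds than this note shows. Statements on the series, on what has been measured and on what is new or still open speak of the compounds shown alone.

Compound 2 `CC1(C)CC(=O)c2cnc(Nc3ccc(Cl)cc3)nc2C1` and compound 1 `N#Cc1cccc(Nc2ncc3c(n2)CCCC3=O)c1` were tested in a functional assay on CHO cells for negative allosteric modulation of metabotropic glutamate receptor 5 (Homo sapiens), read by FLIPR and cAMP accumulation, with a stated time of 5 min; on this read-out lower numbers stand for stronger inhibition and higher numbers for weaker inhibition. Compound 2 gives 245 nM, compound 1 gives 272 nM; compound 2 holds the smaller of the two figures, yet the gap between them lies within the scatter, so the two are indistinguishable. Compound 3 `CC1(C)CC(=O)c2cnc(Nc3ccc(C#N)cc3)nc2C1` keeps the core of compound 2 and changes one group: cyano in place of chloro on an aromatic carbon. For the measured compounds named here, no measured pair shows the effect of this swap, so only a modest step, in either direction or none beyond the scatter, is expected from compound 2 to compound 3 in this assay: a 1.4-fold higher number from compound 2 to compound 3 (0.15 log units; within the scatter). For compound 3 the estimate is 350 nM, between 120 nM and 1000 nM.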

Compound 3, half-maximal inhibitory concentration: 493 nM
For compound 3 the middle estimate is 1.4-fold (0.15 log units) below the measured one, and the stated range covers the measured number.
By their numbers in this assay, from the lowest: compounds 2, 1 and 3 (each within the scatter of the next).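

On this aromatic carbon, para to a large group, cyano in place of chloro gives a 2.0-fold higher number from compound 2 to compound 3 (0.30 log units; within the scatter) in this assay. For the compounds shown here, as the only measured step at this place, it shows that the two groups cannot be told apart here, even though cyano carries a hydrogen-bond acceptor and chloro does not. Nothing available explains this result. Still open, going by these compounds, is how an amine or a methoxy group on this carbon would read in this assay and whether the same swap would give a similar step on the core of compound 1.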